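The source may report more compounds than this note shows. Statements on the series, on what has been measured and on what is new or still open speak of the compounds shown alone.

Measured compounds:
compound 1 `Cc1ccc(/C=C2\S/C(=N\c3csc(-c4ccc(Cl)cc4)c3)NC2=O)cc1`: 6400 nM
compound 2 `O=C1N/C(=N/c2csc(-c3ccc(Cl)cc3)c2)S/C1=C\c1ccc(Br)cc1`: 2000 nM

In a functional assay on HT-29 cells (Homo sapiens) for cytotoxicity, read by MTT assay, with a stated time of 72 h (on this read-out higher numbers stand for weaker inhibition and lower numbers for stronger inhibition), compound 2 gives 2000 nM, the lower of the two numbers, while compound 1 gives 6400 nM. For the measured compounds named here, the only measured step is a 3.2-fold lower number from compound 1 to compound 2 (0.51 log units; beyond the scatter). Compound 3 `O=C1N/C(=N/c2csc(-c3ccc(Cl)cc3)c2)S/C1=C\c1ccc(O)cc1` differs from compound 2 by hydroxy in place of bromo on an aromatic carbon. That measured step swapped methyl for bromo, not bromo for hydroxy, so it bears on this change only loosely and gives no direct guide. With that thin basis, a modest move toward a higher number is expected for compound 3, as a 2.0-fold higher number from compound 2 to compound 3 (0.30 log units; within the scatter). The estimate for compound 3 is 4000 nM, within 1000 nM to 16000 nM.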

Compound 3, half-maximal inhibitory concentration: > 50000 nM
Compound 3: a limit, no number; the forecaster's own chance of this, stated with the estimate: 5%; middle value at least 12-fold (1.09 log units) away from the limit.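

In this assay compound 3 gives a limit and not a number: the limit of > 50000 nM in this assay, at which 1 of the 3 values shown sits. The earlier step showed only a modest shift at this place on the aromatic ring, whereas hydroxy brings an at least 25-fold higher number from compound 2 to compound 3 (1.39 log units; beyond the scatter). Measured against the methyl group as well, hydroxy brings an at least 7.8-fold higher number from compound 1 to compound 3 (0.89 log units; beyond the scatter), so this position does not accept every small group equally. From the compounds shown here alone, how far compound 3 lies beyond its limit stays open. So does whether a methoxy group or an amine at this place would behave like hydroxy or like bromo.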